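The compounds below may be only part of what the source reports. "The series", "measured", "known", "first", "only" and "open" are said of these compounds alone.

Compound 1, `CC1(C)[C@H]2CC[C@]1(C)N(Cc1cn(-c3ccccc3C#N)nn1)C(=O)C2`: 110 nM
Compound 2, `CC1(C)[C@H]2CC[C@]1(C)N(Cc1cn(-c3ccccc3F)nn1)C(=O)C2`: 300 nM
Compound 3, `CC1(C)[C@H]2CC[C@]1(C)N(Cc1cn(-c3ccc(O)cc3)nn1)C(=O)C2`: 410 nM

All three share one core and differ only in the aryl group attached to an aromatic nitrogen of the five-membered ring, and all were tested in a functional assay on OVCAR-3 cells (Homo sapiens) for inhibition, read by MTT assay, with a stated time of 24 h; a higher number here means a weaker inhibitor, a lower number a stronger inhibitor. Among the three numbers, compound 2 stands second highest. Its nearest neighbour is compound 3, and the step of a 1.4-fold higher number from compound 2 to compound 3 (0.14 log units; within the scatter) lies within the scatter, so no order between these two can be claimed. Its furthest neighbour is compound 1, and the step of a 2.7-fold higher number from compound 1 to compound 2 (0.44 log units; beyond the scatter) lies beyond the scatter.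

Compound 4, `Cc1ccc(-n2cc(CN3C(=O)C[C@@H]4CC[C@@]3(C)C4(C)C)nn2)cc1`, has not yet been measured in this assay. Its change from compound 2 is 4-methylphenyl in place of 2-fluorophenyl on an aromatic nitrogen.

Among the compounds with values here, two measured steps bear on this. The step of a 2.7-fold higher number from compound 1 to compound 2 (0.44 log units; beyond the scatter) shows that swapping one group on the phenyl ring for another can shift the number beyond the scatter. The step of a 1.4-fold higher number from compound 2 to compound 3 (0.14 log units; within the scatter) shows that replacing 2-fluorophenyl by 4-hydroxyphenyl left the number within the scatter. Because the step of a 1.4-fold higher number from compound 2 to compound 3 (0.14 log units; within the scatter) stayed within the scatter for a comparable exchange, the expected step of a 1.3-fold higher number from compound 2 to compound 4 (0.12 log units; within the scatter) is small, with only a slight lean toward a higher number. Compound 4 is therefore estimated at 400 nM, within a range from 150 nM to 1100 nM.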

Compound 4, half-maximal inhibitory concentration: 40 nM
Estimate against measurement, compound 4: 10-fold (1.00 log units) above; the whole stated range lies above it.
By their numbers in this assay, from the lowest: compound 4; then compound 1; then compounds 2 and 3 (each within the scatter of the next).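

Within the data shown here, the aryl group on this ring nitrogen can move the number much further than the earlier compounds showed. In this assay, 4-methylphenyl in place of 2-fluorophenyl, two groups with 7 heavy atoms each and no hydrogen-bond donors or acceptors, gives a clear drop (a 7.5-fold lower number from compound 2 to compound 4 (0.88 log units; beyond the scatter)). Methyl in place of hydroxy, which keeps the rest of the molecule unchanged, gives the largest step in the set (a 10-fold lower number from compound 3 to compound 4 (1.01 log units; beyond the scatter)), and compound 4 also falls clearly below the previous lowest compound (a 2.8-fold lower number from compound 1 to compound 4 (0.44 log units; beyond the scatter)), making it the strongest inhibitor of the four, although nothing available explains why this methyl group has such an effect.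

The compounds shown leave open whether the gain belongs to the methyl group itself or to where it sits on the phenyl ring, since 2-methylphenyl is not among them and the step from 2-fluorophenyl changes both at once. They also leave open whether a longer chain, as in 4-ethylphenyl, or an amine, as in 4-aminophenyl, would keep the number as low.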